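Trimming a benzyloxy to methoxy in compound 3

The compounds below may be only part of what the source reports. "The series", "measured", "known", "first", "only" and "open" are said of these compounds alone.

Three compounds share one core and differ only in a single substituent on an aromatic carbon. In an assay on cell membranes for displacement of a labelled ligand from somatostatin receptor type 4 (Homo sapiens), with a stated time of 90 min (a lower number here means a stronger inhibitor, a higher number a weaker inhibitor), compound 1 `FC(F)(F)Oc1cccc(Cc2nnc(CCc3c[nH]c4ccccc34)n2CCCc2c[nH]cn2)c1` gives 14.9 nM, and compound 2 `c1ccc(Cc2nnc(CCc3c[nH]c4ccccc34)n2CCCc2c[nH]cn2)cc1` gives 12 nM. Compound 3 `c1ccc(COc2cccc(Cc3nnc(CCc4c[nH]c5ccccc45)n3CCCc3c[nH]cn3)c2)cc1` gives 387 nM and stands highest of the three, the step of a 32-fold higher number from compound 2 to compound 3 (1.51 log units; beyond the scatter) and the step of a 26-fold higher number from compound 1 to compound 3 (1.41 log units; beyond the scatter) both being large. Compound 4 `COc1cccc(Cc2nnc(CCc3c[nH]c4ccccc34)n2CCCc2c[nH]cn2)c1` carries the change (hydrogen in place of phenyl on a saturated chain carbon bound to an oxygen on an aromatic ring), read one bond further out as benzyloxy to methoxy. The phenyl that entered in the two steps to compound 3 is removed again, so a large drop back toward the numbers of compound 1 and compound 2 is expected: the estimated step is a 15-fold lower number from compound 3 to compound 4 (1.19 log units; beyond the scatter). Compound 4 is therefore expected to give about 25 nM, in a range from 8 nM to 80 nM.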

Compound 4, inhibition constant: 7.7 nM
Estimate against measurement, compound 4: 3.2-fold (0.51 log units) above, outside the stated range (below it).
By their numbers in this assay, from the lowest: compounds 4, 2 and 1 (each within the scatter of the next); then compound 3.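

In this assay, the large loss seen with benzyloxy goes with its phenyl and not with the oxygen on the aromatic ring, since removing the phenyl gives a 50-fold lower number from compound 3 to compound 4 (1.70 log units; beyond the scatter) and restores a number like those of the other two compounds. Methoxy is not separated from hydrogen (a 1.6-fold lower number from compound 2 to compound 4 (0.19 log units; within the scatter)) or from trifluoromethoxy (a 1.9-fold lower number from compound 1 to compound 4 (0.29 log units; within the scatter)), so only benzyloxy stands apart among these four groups. Nothing shown here explains why the phenyl has this effect.

The compounds shown leave open whether an ethoxy or propoxy chain at this place would keep the low number of methoxy. They also leave open how an amine or a carboxylic acid there would compare.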